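Adding a second fluorine to the phenyl of compound 3

The source may hold more compounds than are shown below. What is called first, only, known or untested is meant among the compounds shown, and "the series" means these compounds.

Three compounds share a core and differ only in the aryl group on an amine nitrogen in a ring. Compound 1 `COc1ccc(N2CCN(Cc3csc(N)c3C(=O)c3ccc(Cl)cc3)CC2)cc1` gives -52% in a functional assay on CHO cells with adenosine receptor A1 (Homo sapiens) as the target, read by cAMP accumulation and immunoassay, with a stated time of 6 min, tested at 10 uM; a higher number here means a weaker effect of the compound at the concentration tested, a lower number a stronger effect. Compound 2 `Nc1scc(CN2CCN(c3cccc4ccccc34)CC2)c1C(=O)c1ccc(Cl)cc1` gives -21% in this assay, and compound 3 `Nc1scc(CN2CCN(c3ccccc3F)CC2)c1C(=O)c1ccc(Cl)cc1` gives -15% in this assay. The swap from the aryl of compound 1 produced a number 31 percentage points higher from compound 1 to compound 2 (beyond the scatter) and a number 37 percentage points higher from compound 1 to compound 3 (beyond the scatter), while between the other two aryl groups the change was only a number 6 percentage points higher from compound 2 to compound 3 (within the scatter). Compound 3 therefore sits well above compound 1 and at a distance from compound 2 that is within the usual scatter.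

Compound 4 `Nc1scc(CN2CCN(c3ccc(F)cc3F)CC2)c1C(=O)c1ccc(Cl)cc1` differs from compound 3 by a single change: fluoro in place of hydrogen on an aromatic carbon. Within the data shown here, none of the measured steps bears directly on this change, since each of them exchanged the whole aryl group rather than adding one fluorine to it. Among the measured compounds shown here, the only step touching a fluorophenyl was a number 6 percentage points higher from compound 2 to compound 3 (within the scatter), which gives no sign of a large shift. In this assay compound 4 is therefore expected to show no change at the digits printed from compound 3 to compound 4 (within the scatter), a step that need not exceed the scatter. The estimate for compound 4 is -15%, expected to lie between -38% and 5%.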

Compound 4, a percentage reported as activity, at one concentration (the size of the read-out at that concentration, not a potency): -82%
For compound 4 the middle estimate is 67 percentage points above the measured one; the whole stated range lies above it.
By their numbers in this assay, from the lowest: compound 4; then compound 1; then compounds 2 and 3 (each within the scatter of the next).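

Adding one fluoro to the 2-fluorophenyl, on the aromatic carbon meta to a fluoro group and para to a large group, gave a number 67 percentage points lower from compound 3 to compound 4 (beyond the scatter) in this assay and showed that this single position on the aryl group can move the read-out strongly, something the earlier exchanges of whole aryl groups could not isolate. The 2,4-difluorophenyl also stands apart from the other two aryl groups, with a number 61 percentage points lower from compound 2 to compound 4 (beyond the scatter) and a number 30 percentage points lower from compound 1 to compound 4 (beyond the scatter) placing compound 4 at the lowest number of the four, so the 4-methoxyphenyl of compound 1 no longer marks the strongest effect in the set. Nothing measured here explains why this added fluoro has so large an effect.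

As far as these compounds go, it remains open whether the shift belongs to fluoro itself or would also follow chloro, methyl or a nitrile on the same carbon. From the compounds shown here alone, it is equally open whether the fluoro on this carbon would act alone in a 4-fluorophenyl, or whether the effect depends on the 2-fluoro that compound 4 also carries.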